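The source may report more compounds than this note shows. Statements on the series, on what has been measured and on what is new or still open speak of the compounds shown alone.

Three compounds have so far been measured in a functional assay; a lower number here means a stronger inhibitor, a higher number a weaker inhibitor:

compound 1, `CC(C)=CCOc1ccc2c(c1)OC(c1ccccc1F)CC2=O`: 6360 nM
compound 2, `CC(C)=CCOc1ccc2c(c1)OC(c1ccc(F)cc1)CC2=O`: 7320 nM
compound 3, `CC(C)=CCOc1ccc2c(c1)OC(c1cccc(Cl)c1)CC2=O`: 6300 nM

On these numbers compound 1 stands second highest of the three. Its nearest neighbour is compound 3, with a 1.0-fold lower number from compound 1 to compound 3 (0.00 log units; within the scatter), and its furthest is compound 2, with a 1.2-fold higher number from compound 1 to compound 2 (0.06 log units; within the scatter). The remaining pair gives a 1.2-fold lower number from compound 2 to compound 3 (0.07 log units; within the scatter). Every one of these steps lies within the usual scatter, so the three values cannot be ordered against one another.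

Compound 4, `CC(C)=CCOc1ccc2c(c1)OC(c1cccc(Br)c1)CC2=O`, has not yet been measured. It differs from compound 1 in a single place: 3-bromophenyl in place of 2-fluorophenyl on a saturated ring carbon. The measured steps that bear on this change are the three exchanges of one halogen-bearing phenyl for another on the same saturated ring carbon, and none of them moved the number beyond the scatter. The 3-bromophenyl of compound 4 most resembles the 3-chlorophenyl of compound 3, whose value is indistinguishable from that of compound 1. The expectation is therefore for no step beyond the scatter in this assay, that is a 1.1-fold lower number from compound 1 to compound 4 (0.03 log units; within the scatter). Compound 4 is estimated at 6000 nM, with a range from 3000 nM to 12000 nM.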

Compound 4, half-maximal inhibitory concentration: 5280 nM
Compound 4: the middle estimate sits 1.1-fold (0.06 log units) above what was measured; measured number inside the range.
By their numbers in this assay, from the lowest: compounds 4, 3, 1 and 2 (each within the scatter of the next).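

In this assay, putting 3-bromophenyl in place of 2-fluorophenyl on the saturated ring carbon next to the ring oxygen gives a 1.2-fold lower number from compound 1 to compound 4 (0.08 log units; within the scatter) and so leaves the number within the scatter, while the cleaner comparison, bromo in place of chloro on an aromatic carbon, gives a 1.2-fold lower number from compound 3 to compound 4 (0.08 log units; within the scatter) and shows that this halogen exchange is also not resolved by the assay. Even the largest step yet seen among these compounds, a 1.4-fold lower number from compound 2 to compound 4 (0.14 log units; within the scatter) on exchanging 3-bromophenyl for 4-fluorophenyl, stays within the scatter, so 2-fluorophenyl, 4-fluorophenyl, 3-chlorophenyl and 3-bromophenyl cannot be told apart at this position. No independent measurement is available to account for this flat result.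

As far as these compounds go, all four compounds carry a single halogen on this phenyl, so it remains open whether an unsubstituted phenyl, or a phenyl bearing an amine or a carboxylic acid, would produce a step beyond the scatter. From the compounds shown here alone, it is equally open whether a change away from this position, such as a longer chain on the ether oxygen of the shared core, would move the number more than these halogen exchanges do.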